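The source may report more compounds than this note shows. Statements on the series, on what has been measured and on what is new or still open speak of the compounds shown alone.

Compound 2, `CCCCCCCCCCCCNC(=O)[C@@H](NC(=O)c1ccco1)[C@@H](C)O`, is the reference point for this step. In a functional assay on A-431 cells (Homo sapiens) for cytotoxicity, read by MTT assay, with a stated time of 48 h (on this read-out lower numbers stand for stronger inhibition and higher numbers for weaker inhibition), compound 2 gives 92400 nM, a number that lies between those of its two neighbours, each within the scatter of it. Compound 1, `CCCCCCCCNC(=O)[C@@H](NC(=O)c1ccco1)[C@@H](C)O`, gives 64500 nM, and compound 3, `CCCCCCCCCCCCNC(=O)[C@@H](NC(=O)c1cc2ccccc2n1C)[C@@H](C)O`, gives 169000 nM. The two measured steps that connect these three are small: a 1.4-fold higher number from compound 1 to compound 2 (0.16 log units; within the scatter), and a 1.8-fold higher number from compound 2 to compound 3 (0.26 log units; within the scatter).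

Compound 4, `CCCCCCCCCCCCNC(=O)[C@@H](NS(=O)(=O)c1cccs1)[C@@H](C)O`, has not yet been measured. It differs from compound 2 in one place: (thiophen-2-yl)sulfonyl in place of (furan-2-yl)carbonyl on an amine nitrogen. Within the data shown here, neither measured step touches the amine nitrogen, and neither exchanges a carbonyl for a sulfonyl, so no step bears directly on this change. What the two steps do show is that a longer chain and a different aromatic group on the carbonyl carbon each left the number within the scatter, and there is no measured case of a larger movement in this series. On that basis no step beyond the scatter is expected in this assay from compound 2 to compound 4, and the estimated step is a 1.1-fold higher number from compound 2 to compound 4 (0.03 log units; within the scatter). Compound 4 is therefore expected to give about 100000 nM, with a range from 40000 nM to 250000 nM.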

Compound 4, half-maximal inhibitory concentration: 22000 nM
Beside the measured number, compound 4's estimate is 4.5-fold (0.66 log units) above it; measured number below the stated range.
By their numbers in this assay, from the lowest: compound 4; then compounds 1, 2 and 3 (each within the scatter of the next, the first and the last beyond it).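

In this assay, the exchange of (furan-2-yl)carbonyl for (thiophen-2-yl)sulfonyl on the amine nitrogen gives a 4.2-fold lower number from compound 2 to compound 4 (0.62 log units; beyond the scatter), the only step shown in this series that lies beyond the scatter and one toward stronger inhibition. This shows that the number can respond to a change at this place, whereas the longer chain and the exchange of the aromatic group on the carbonyl carbon had each stayed within the scatter. The change alters both the linking group and the ring at once, and no available evidence accounts for the step or says which of the two alterations matters.

The compounds shown leave open whether the sulfonyl or the thiophene carries the step, a question that (furan-2-yl)sulfonyl and (thiophen-2-yl)carbonyl on the same nitrogen would separate. They also leave open whether the same exchange moves the number on the shorter chain of compound 1, and how a phenylsulfonyl or methylsulfonyl group would read at this place.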